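From methoxymethoxy to methoxy: what compound 3 may show

This account rests on a few compounds, and the source may have more. Where it says the series, first, only, none or still open, it means among the compounds named here.

Measured so far:
Compound 1 `C=C[C@@H]1C[C@@H](Cc2ccc(OC)c(O)c2)[C@H]2C(=O)C=CC(=C)[C@H]21`: 1.59 nM
Compound 2 `C=C1C=CC(=O)[C@@H]2[C@H](Cc3ccc(OCOC)c(F)c3)CC[C@H]12`: 76.6 nM

In a functional assay on KB cells (Homo sapiens) for antiproliferative activity, with a stated time of 72 h (a lower number here means a stronger inhibitor, a higher number a weaker inhibitor), compound 2 has the higher number of the two, and its gap to compound 1 lies beyond the scatter. The two compounds differ in more than one place, so that gap cannot be tied to any single structural change.

Compound 3 `C=C1C=CC(=O)[C@@H]2[C@H](Cc3ccc(OC)c(F)c3)CC[C@H]12` departs from compound 2 in one place: hydrogen in place of methoxy on a saturated chain carbon bound to an oxygen on an aromatic ring, which turns methoxymethoxy into methoxy. Within the data shown here, no measured step shows this change, so the expectation rests on thin evidence. Compound 1 carries a methoxy group and reads 1.59 nM, but it also differs from compound 2 elsewhere.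

A modest move to a lower number is expected in this assay, and the estimate is a 2.6-fold lower number from compound 2 to compound 3 (0.41 log units; beyond the scatter) with real uncertainty. For compound 3 the estimated value is 30 nM, with an expected range (6 nM to 150 nM).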

Compound 3, half-maximal inhibitory concentration: 2.77 nM
Compound 3: the middle estimate sits 11-fold (1.03 log units) above what was measured; the whole stated range lies above it.
By their numbers in this assay, from the lowest: compounds 1 and 3 (each within the scatter of the next); then compound 2.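

In this assay, the change from methoxymethoxy to methoxy, with hydrogen in place of methoxy on a saturated chain carbon bound to an oxygen on an aromatic ring, gives a 28-fold lower number from compound 2 to compound 3 (1.44 log units; beyond the scatter). The gap between compound 1 and compound 2 could not be tied to any single structural change, whereas this pair differs in one place only, so a large difference in the number can now be assigned to this one change on the shared core. Nothing at hand bears on what lies behind a step of this size, and the numbers record only that it occurs.

The compounds shown leave open how this place would read with an ethoxy group, a longer chain or an amine, as they cover only methoxymethoxy and methoxy there, and so they do not show whether the number keeps moving as the group shrinks or grows. Also open, going by these compounds, is whether the same change would give a step of similar size on the core of compound 1, which differs from compound 3 elsewhere.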